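This account rests on a few compounds, and the source may have more. Where it says the series, first, only, none or still open, it means among the compounds named here.

Compound 2 `NC(=O)NC/C=C\CN(C[C@H]1Cc2ccccc2CN1)[C@H]1CCCc2cccnc21` sits second highest of the three numbers measured in a functional assay on CCRF-CEM cells for antagonist activity at C-X-C chemokine receptor type 4 (Homo sapiens), read by calcium flux, with stated times of 25 min and 90 s (a lower number here means a stronger inhibitor, a higher number a weaker inhibitor), where compound 2 gives 210 nM. Compound 1 `N[C@H]1CC[C@H](CN(C[C@H]2Cc3ccccc3CN2)[C@H]2CCCc3cccnc32)CC1` gives 280 nM in this assay, and compound 3 `FC1(F)CCC(NC/C=C\CN(C[C@H]2Cc3ccccc3CN2)[C@H]2CCCc3cccnc32)CC1` gives 98 nM. Compound 4 `C/C(=C/CN)CN(C[C@H]1Cc2ccccc2CN1)[C@H]1CCCc2cccnc21` differs from compound 2 by a group of 5 heavy atoms (4 carbon, 1 nitrogen; no ring) in place of a group of 7 heavy atoms (4 carbon, 2 nitrogen, 1 oxygen; no ring), on a saturated chain carbon bound to an amine nitrogen. Going by the values given here, two measured steps bear on this change: the exchange at the same place, a 1.3-fold lower number from compound 1 to compound 2 (0.12 log units; within the scatter), and the exchange on the amine nitrogen, a 2.1-fold lower number from compound 2 to compound 3 (0.33 log units; beyond the scatter). The entering group carries a primary amine, as does compound 1, whose 280 nM lies close to the number for compound 2. Compound 4 is therefore expected to show only a small shift, a 1.2-fold higher number from compound 2 to compound 4 (0.08 log units; within the scatter). The estimate for compound 4 is 250 nM, with a range from 100 nM to 650 nM.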

Compound 4, half-maximal inhibitory concentration: 28 nM
Compound 4: the middle estimate sits 8.9-fold (0.95 log units) above what was measured, and the stated range ends above it.
By their numbers in this assay, from the lowest: compound 4; then compound 3; then compounds 2 and 1 (each within the scatter of the next).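

Within the earlier compounds, the exchange at this saturated chain carbon bound to an amine nitrogen had moved the number only within the scatter, but in this assay the group in compound 4 gives a clear gain, with a 7.5-fold lower number from compound 2 to compound 4 (0.88 log units; beyond the scatter) and with a 10-fold lower number from compound 1 to compound 4 (1.00 log units; beyond the scatter) as well. Compound 1 also carries a primary amine, so that group alone does not set the number at this place; the open chain of compound 4 and the carbocycle of compound 1 part clearly here.

Going by these compounds, whether a longer chain ending in the primary amine, or a dimethylamine in its place, would hold this gain remains open. Nothing in the data given explains the gain.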